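A few compounds are considered here, and "the series" means these few. Any claim that something is new, unique, unknown or untested is made for them only; others in the source may bear on it.

In a functional assay on the whole organism (strain ICR) for inhibition, with Mus musculus as the target, with a stated time of 4 h, at a dose of 10 mg/kg by the oral route (on this read-out lower numbers stand for less inhibition and higher numbers for more inhibition at the one dose given (going by the name of the read-out)), compound 3 `CC(C)S(=O)(=O)CCC12CCC(c3nnc(-c4ccccc4C(F)(F)F)n3C)(CC1)CC2` gives 88%, the second highest of three numbers: compound 2 `Cn1c(-c2ccccc2C(F)(F)F)nnc1C12CCC(CCCC(C)(F)F)(CC1)CC2` gives 99%, while compound 1 `Cn1c(-c2ccccc2C(F)(F)F)nnc1C12CCC(CCS(=O)(=O)C(C)(C)C)(CC1)CC2` gives 65%. Compound 4 `CCCCCC12CCC(c3nnc(-c4ccccc4C(F)(F)F)n3C)(CC1)CC2` differs from compound 3 by a single change: propyl in place of isopropylsulfonyl on a saturated chain carbon, two bonds along the chain from a saturated ring carbon. Within the data shown here, two measured steps bear on it. The step of a number 34 percentage points higher from compound 1 to compound 2 (beyond the scatter) shows a large gain when a sulfonyl-bearing chain is exchanged for a chain without one, and the step of a number 11 percentage points lower from compound 2 to compound 3 (beyond the scatter) shows a modest loss when a sulfonyl comes back. Taking the isopropylsulfonyl away for a plain propyl points the same way, so compound 4 is expected to move by a number 8 percentage points higher from compound 3 to compound 4 (within the scatter). Compound 4 is estimated at 96%, within a range from 86% to 100%.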

Compound 4, a percentage reported as inhibition, in the whole organism at one dose (the size of the read-out at that dose, not a potency): 98%
Beside the measured number, compound 4's estimate is 2 percentage points below it; the measured number falls inside the stated range.
By their numbers in this assay, from the lowest: compound 1; then compounds 3, 4 and 2 (each within the scatter of the next, the first and the last beyond it).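

In this assay, the step of a number 10 percentage points higher from compound 3 to compound 4 (within the scatter) means that a plain propyl and an isopropylsulfonyl cannot be told apart at this position, so a sulfonyl is not needed there for a high number. The step of a number 1 percentage points lower from compound 2 to compound 4 (within the scatter) says the same of ethyl against 1,1-difluoroethyl, while the step of a number 33 percentage points higher from compound 1 to compound 4 (beyond the scatter) leaves only the (tert-butyl)sulfonyl standing apart. Nothing measured here gives a reason for these numbers. As far as these compounds go, whether an amine or a carboxylic acid on this chain, or a longer chain, would keep the number this high stays open.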